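Cytotoxicity of biaryl amides: phenoxy to trifluoromethoxy

The source may hold more compounds than are shown below. What is called first, only, known or untested is meant among the compounds shown, and "the series" means these compounds.

Compound 1, `CC(C)N(Cc1cccc(OCCCCCC(=O)O)c1)C(=O)c1ccc(-c2cccc3ccccc23)cc1`: in an ADME assay on HEK293 cells (Homo sapiens) for cytotoxicity, read by CellTiter-Glo and resazurin assay, with a stated time of 72 h (a higher number here means that more compound is needed for the effect, a lower number that less compound is needed), compound 1 gives only a limit, > 26000 nM.
Compound 2, `CC(C)N(Cc1cccc(OCCCCCC(=O)O)c1)C(=O)c1ccc(-c2cccc(Oc3ccccc3)c2)cc1`: in this assay compound 2 gives only a limit, > 18700 nM.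
Compound 3, `CC(C)N(Cc1cccc(OCCCCCC(=O)O)c1)C(=O)c1ccc(-c2cc3ccccc3n2S(=O)(=O)c2ccccc2)cc1`: in this assay compound 3 gives only a limit, > 26000 nM.

None of the three measured compounds gives a number in this assay; each sits at a limit of the assay. Compound 2 stands at the limit of > 18700 nM in this assay, at which 1 of the 3 values shown sits, while compounds 1 and 3 stand at the limit of > 26000 nM in this assay, at which 2 of the 3 values shown sit. Among the compounds with values here, no step between measured compounds is known, and a pair of limits shows only that neither compound reached the effect within the tested range.

The unmeasured compound 4, `CC(C)N(Cc1cccc(OCCCCCC(=O)O)c1)C(=O)c1ccc(-c2cccc(OC(F)(F)F)c2)cc1`, differs from compound 2 in one place: trifluoromethyl in place of phenyl on an oxygen on an aromatic ring. The shared core and the acid-bearing chain stay the same.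

With all three values sitting at limits, no step beyond the scatter is expected in this assay for this change, in either direction. Compound 4 is therefore expected to remain at or beyond the limit as well, with an estimated value of 30000 nM, in the range from 10000 nM to 100000 nM. The step from compound 2 is expected to be a step that the limit leaves unreadable from compound 2 to compound 4, which is no more than the scatter of the assay.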

Compound 4, half-maximal effective concentration: > 26000 nM
Compound 4: no number, only a limit; the forecaster's own chance of this, stated with the estimate: 85%; the middle value does not contradict the limit.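

In this assay compound 4 gives > 26000 nM, a limit and not a number. Compound 2 likewise gives only a limit, > 18700 nM. The steps to compound 4 from compound 1 and compound 2 therefore cannot be read. The compounds shown leave open what concentration any of them needs for the effect, and whether phenoxy to trifluoromethoxy changes it.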